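The source may hold more compounds than are shown below. What is called first, only, known or untested is meant among the compounds shown, and "the series" means these compounds.

Among the two compounds measured so far in a physicochemical assay for lipophilicity, read by HPLC, at pH 7.5 (on this read-out higher numbers stand for higher lipophilicity and lower numbers for lower lipophilicity), compound 2 `CCOc1ccccc1-c1ccc(-c2nc3cnccc3c(C[C@H](C)C(N)=O)c2C#N)cc1` stands highest at 3, and compound 1 `CCOc1ccccc1-c1ccc(-c2nc3cnccc3c(NC(C)C(=O)O)c2C#N)cc1` gives 2.1. Compound 3 `CCOc1ccccc1-c1ccc(-c2nc3cnccc3c(NC(C(N)=O)C3CC3)c2C#N)cc1` has not yet been measured. It keeps the shared core and changes one substituent, on an aromatic carbon ortho to a cyano group and opposite the ring nitrogen: a group of 8 heavy atoms (5 carbon, 2 nitrogen, 1 oxygen; one three-membered non-aromatic ring of carbon only) in place of a group of 6 heavy atoms (4 carbon, 1 nitrogen, 1 oxygen; no ring), on an aromatic carbon. The 2-carbamoylpropyl group leaves, and the group that enters brings a three-membered non-aromatic ring of carbon only.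

Within the data shown here, only one measured step bears on this change: a number 0.90 log units higher from compound 1 to compound 2 (beyond the scatter), where 2-carbamoylpropyl took the place of (1-carboxyethyl)amino on an aromatic carbon. It is a single step between a different pair of groups, so it offers only loose guidance. Compound 3 carries a carbamoyl group, as does compound 2 at 3, and lacks the carboxy group of compound 1 at 2.1, so a value near the higher of the two is expected. The expected outcome is a number 0.10 log units higher from compound 2 to compound 3 (within the scatter), which means no clear shift beyond the scatter. For compound 3 the estimate is 3.1, with an expected range from 2.6 to 3.6.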

Compound 3, distribution coefficient: 3
Compound 3: middle estimate off by 0.10 log units, on the high side, within the range that was stated.
By their numbers in this assay, from the lowest: compound 1; then compounds 2 and 3 (each within the scatter of the next).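

In this assay, the entering group is larger than 2-carbamoylpropyl and carries more hydrogen-bond donors and acceptors, yet the result is no change at the digits printed from compound 2 to compound 3 (within the scatter), so at this position these added features come with no shift that can be told from the scatter. The other new comparison keeps the nitrogen on the aromatic ring and changes only the group on it, giving a number 0.90 log units higher from compound 1 to compound 3 (beyond the scatter), which matches the size of a number 0.90 log units higher from compound 1 to compound 2 (beyond the scatter); among these three compounds, the two with a carbamoyl group therefore sit together, clear of the one with a carboxy group, and none goes against that pattern. No measurement shown explains why the numbers fall this way.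

On these data alone, compound 3 differs from compound 2 in its link to the aromatic carbon, its three-membered ring and its branching all at once, so the contribution of each part stays unknown, and opposing contributions could be hidden behind the unchanged number. As far as these compounds go, how a simple amine, a longer chain or a cyclobutyl ring in place of the three-membered ring would read at this position also remains open.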